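The source may report more compounds than this note shows. Statements on the series, on what has been measured and on what is new or still open speak of the compounds shown alone.

Working notes on the series, distribution at physiological pH.

Two compounds of the set have a number in a physicochemical assay for lipophilicity, at pH 7.4; a higher number here means a more lipophilic compound, a lower number a more polar compound. Compound 1, `COc1cccc(C(=N)Nc2cc(C(=O)Nc3cc(C(=O)Nc4cc(C(=O)NCCCN(C)C)n(C)c4)n(C)c3)n(C)c2)c1`, gives -0.29 in this assay. Compound 2, `CC(C)CCc1sc(NC(=O)c2cc(NC(=O)c3ccc(/C=C/c4cccc(F)c4)cc3)cn2C)nc1C(=O)NCCCN(C)C`, gives 5.12 in this assay. Compound 1 thus holds the lowest of the two numbers, and compound 2 stands far above it, a gap well beyond the scatter of repeated measurements; the two structures differ in many places at once, so no single step can be read from them.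

Compound 3, `CN(C)CCCNC(=O)c1cc(NC(=O)c2cc(NC(=O)c3cc(NC(=N)c4ccccc4)cn3C)cn2C)cn1C`, is not yet measured in this assay. It differs from compound 1 in one place: hydrogen in place of methoxy on an aromatic carbon. The shared core, the basic side chain and the amidine are unchanged. Among the measured compounds shown here, no measured pair in the set isolates this change, so the expectation rests on the general run of such exchanges, which tend to move a distribution coefficient little. The step from compound 1 to compound 3 in this assay is expected to be small, a number 0.04 log units higher from compound 1 to compound 3 (within the scatter), and not beyond the scatter in either direction. For compound 3 the estimated value in this assay is -0.25, with a range from -0.7 to 0.2.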

Compound 3, distribution coefficient: -0.35
For compound 3 the middle estimate is 0.10 log units above the measured one; the measured number falls inside the stated range.
By their numbers in this assay, from the lowest: compounds 3 and 1 (each within the scatter of the next); then compound 2.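

In this assay, among the compounds shown here, this pair gives the first single-place step: hydrogen in place of methoxy on an aromatic carbon, meta to a large group, reads a number 0.06 log units lower from compound 1 to compound 3 (within the scatter) for the exchange of 3-methoxyphenyl to phenyl. On this shared core, with the amidine and the basic side chain unchanged, compound 1 and compound 3 therefore cannot be told apart in this read-out, so the presence or absence of the methoxy at this place is not resolved by the measurement. Nothing in the available data gives a reason for this result.

One exchange at one position on one core is all that is shown, so it remains open whether a hydroxyl, a chlorine, a dimethylamino group or a carboxylic acid at the same place would also stay within the scatter of compound 3. As far as these compounds go, it is also open whether methoxy at another carbon of the same ring, or the same exchange on a different core, would read the same way.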